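Extending the branched acyl chain of compound 3

The compounds below may be only part of what the source reports. "The series", "measured", "known", "first", "only" and "open" are said of these compounds alone.

Compound 1 `COc1ccc(C(=O)NN(C(=O)c2ccccc2Cl)C(C)(C)C)cc1` gives 51.3 nM in an assay on cells for agonist activity at ecdysone receptor (Bombyx mori), read by a luciferase reporter, with a stated time of 24 h; a higher number here means that more compound is needed for the effect, a lower number that less compound is needed. Compound 2 `CCCCCC(=O)N(NC(=O)c1cc(C)cc(C)c1)C(C)(C)C` gives 8710 nM in this assay, and compound 3 `Cc1cc(C)cc(C(=O)NN(C(=O)CCC(C)C)C(C)(C)C)c1` gives 14500 nM, standing at the top of the three numbers, with compound 2 within the scatter of it and compound 1 far lower. Compound 4 `Cc1cc(C)cc(C(=O)NN(C(=O)CCCC(C)C)C(C)(C)C)c1` differs from compound 3 by isobutyl in place of isopropyl on a saturated chain carbon, two bonds along the chain from a carbonyl carbon. For the measured compounds named here, the only measured step on this chain, a 1.7-fold higher number from compound 2 to compound 3 (0.22 log units; within the scatter), did not move the number beyond the scatter, so a further extension of the same chain is expected to leave the number roughly where it is, with at most a small rise. The estimate for compound 4 is therefore 15000 nM, with a range from 5000 nM to 45000 nM, which amounts to an expected step of a 1.0-fold higher number from compound 3 to compound 4 (0.01 log units; within the scatter).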

Compound 4, half-maximal effective concentration: > 100000 nM
Compound 4: no number, only a limit (the forecaster's own chance of this, stated with the estimate: 10%); middle value at least 6.6-fold (0.82 log units) away from the limit.
By their numbers in this assay, from the lowest: compound 1; then compounds 2 and 3 (each within the scatter of the next). At a limit, above all of these: compound 4.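

The step from propyl to isopropyl had stayed within the scatter, but this position proves sensitive to a further small extension of the chain. Isobutyl in place of isopropyl brings an at least 6.8-fold higher number from compound 3 to compound 4 (0.83 log units; beyond the scatter), and methyl in place of hydrogen on a saturated chain carbon bound to two saturated chain carbons brings an at least 11-fold higher number from compound 2 to compound 4 (1.05 log units; beyond the scatter). For compound 4, this assay gives a limit, not a number: the limit of > 100000 nM in this assay, at which 1 of the 4 values shown sits.

The compounds shown leave open whether a cyclopropyl group, an amine or a carboxylic acid in place of isobutyl would keep the number within the scatter of compound 3.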